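Exchanging One Aryl Group on a Shared Core

The source may report more compounds than this note shows. Statements on the series, on what has been measured and on what is new or still open speak of the compounds shown alone.

Three compounds share one core and differ only in the aryl group on the five-membered ring. In a functional assay on BJAB cells (Homo sapiens) for antiproliferative activity, with a stated time of 4 days (on this read-out lower numbers stand for an effect already at smaller amounts and higher numbers for an effect only at larger amounts of compound), compound 1 `COc1ccc(C)cc1-c1c(C)nn(-c2nc(-c3ccc(Cl)c(Cl)c3)c(SC(C)C)s2)c1C(=O)O` gives 9500 nM. Compound 2 `COc1ccccc1-c1c(C)nn(-c2nc(-c3ccc(Cl)c(Cl)c3)c(SC(C)C)s2)c1C(=O)O` gives 14700 nM. Compound 3 `Cc1nn(-c2nc(-c3ccc(Cl)c(Cl)c3)c(SC(C)C)s2)c(C(=O)O)c1-c1cccc(C(F)(F)F)c1` gives 22000 nM, the highest of the three numbers. The step of a 2.3-fold higher number from compound 1 to compound 3 (0.36 log units; beyond the scatter) was modest, while a 1.5-fold higher number from compound 2 to compound 3 (0.18 log units; within the scatter) stayed within the scatter. Compound 4 `Cc1nn(-c2nc(-c3ccc(Cl)c(Cl)c3)c(SC(C)C)s2)c(C(=O)O)c1-c1ccc(Cl)cc1` carries the change (4-chlorophenyl in place of 3-(trifluoromethyl)phenyl on an aromatic carbon). Both aryl exchanges measured so far moved the read-out only a little, so a small step, if any, is expected here, with the direction uncertain. Over this change the expected step is a 1.5-fold lower number from compound 3 to compound 4 (0.17 log units; within the scatter). Compound 4 is therefore estimated at 15000 nM, within a range from 6000 nM to 40000 nM.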

Compound 4, half-maximal effective concentration: 2500 nM
Compound 4: middle estimate off by 6.0-fold (0.78 log units), on the high side, and the stated range ends above it.
By their numbers in this assay, from the lowest: compound 4; then compounds 1, 2 and 3 (each within the scatter of the next, the first and the last beyond it).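

Swapping in 4-chlorophenyl shows that the aryl group on this carbon can shift the read-out well beyond the scatter in this assay, with an 8.8-fold lower number from compound 3 to compound 4 (0.94 log units; beyond the scatter), a 5.9-fold lower number from compound 2 to compound 4 (0.77 log units; beyond the scatter) and a 3.8-fold lower number from compound 1 to compound 4 (0.58 log units; beyond the scatter). Compound 4 therefore has the lowest number of the four, with its steps to all the others beyond the scatter. Nothing available explains this result. Compound 4 alone carries chlorine on this aryl group, so the data do not separate the effect of that atom from the effect of its place. From the compounds shown here alone, whether a bromine or an amine in place of that chlorine would keep the number this low remains open.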